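The source may hold more compounds than are shown below. What is called first, only, known or untested is meant among the compounds shown, and "the series" means these compounds.

Of the compounds shown here, two have been measured in an assay on isolated protein for inhibition of Rho-associated protein kinase 1 (Homo sapiens), read by scintillation counting, radiometric assay and 33P incorporation, with a stated time of 40 min, in the presence of a further agent that is not named here (on this read-out higher numbers stand for weaker inhibition and lower numbers for stronger inhibition), so far. Compound 1, whose structure is `COc1cc(OCC(=O)Nc2cccc(NC(=O)c3ccc(N(C)C)cc3)c2)ccc1C=O`, gives 3740 nM in this assay. Compound 2, with the structure `CCCC(=O)Nc1cccc(NC(=O)COc2ccc3c(=O)ccoc3c2)c1`, gives 1430 nM and so stands at the lowest of the two numbers, meaning the stronger inhibition of the pair; the gap between it and compound 1 lies beyond the usual scatter of repeated measurements. For the measured compounds named here, the two compounds differ in more than one place, so no single structural step links them, and the gap can only be read as what the two values show.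

Compound 3, with the structure `COc1ccc(C(=O)Nc2cccc(NC(=O)COc3ccc4c(=O)ccoc4c3)c2)cc1`, has not been measured yet. Its difference from compound 2 is a single change: 4-methoxyphenyl in place of propyl on a carbonyl carbon. Nothing measured here shows what this particular change does on the shared core of compound 2, so no direction can be read from a measured step. The change from compound 2 to compound 3 is expected to be small and uncertain in direction, perhaps a slight weakening, as a 1.4-fold higher number from compound 2 to compound 3 (0.15 log units; within the scatter). Compound 3 is therefore expected to give about 2000 nM in this assay, within a range from 600 nM to 6500 nM.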

Compound 3, half-maximal inhibitory concentration: 18 nM
Estimate against measurement, compound 3: 110-fold (2.05 log units) above, and the stated range ends above it.
By their numbers in this assay, from the lowest: compound 3; then compound 2; then compound 1.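

In this assay, for the compounds shown here, this is the first single-change comparison, and it shows that the group on the carbonyl carbon has a very large effect: putting 4-methoxyphenyl in place of propyl gives a 79-fold lower number from compound 2 to compound 3 (1.90 log units; beyond the scatter), with the rest of the structure unchanged. The position is therefore far from indifferent to what sits there, and on this core the 4-methoxyphenyl group goes with much stronger inhibition than propyl. The change alters several things at once, replacing an open chain with an aromatic ring, adding heavy atoms and adding a hydrogen-bond acceptor, and no measurement here bears on which of these matters or why the step is so large.

The compounds shown leave open whether the whole 4-methoxyphenyl group is needed: a plain phenyl ring, or a ring with a hydroxyl group or a chlorine atom in place of the methoxy group, would help to separate the contribution of the ring from that of its oxygen. They also leave open whether a saturated ring such as cyclohexyl or a longer chain such as hexyl would capture any of the same gain.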